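Triazole sulfanyl substitution on the shared core

This account rests on a few compounds, and the source may have more. Where it says the series, first, only, none or still open, it means among the compounds named here.

Measured in a functional assay on BGC-823 cells (Homo sapiens) for inhibition, read by MTT assay, with a stated time of 72 h; a higher number here means a weaker inhibitor, a lower number a stronger inhibitor:
compound 1, `Cc1cc(N2CC[C@@H](C)[C@@H](N(C)c3ncnc4[nH]ccc34)C2)n2ncnc2n1`: 67400 nM
compound 2, `Cc1cc(N2CC[C@@H](C)[C@@H](N(C)c3ncnc4[nH]ccc34)C2)n2nc(SCc3ccc([N+](=O)[O-])cc3)nc2n1`: 59600 nM

For the measured compounds named here, compound 1 carries only hydrogen on the aromatic carbon in question; compound 2, the only other compound measured, carries (4-nitrobenzyl)sulfanyl at that carbon, and the step of a 1.1-fold lower number from compound 1 to compound 2 (0.05 log units; within the scatter) stays within the scatter. Compound 3, `C#CSc1nc2nc(C)cc(N3CC[C@@H](C)[C@@H](N(C)c4ncnc5[nH]ccc45)C3)n2n1`, differs from compound 1 by ethynylsulfanyl in place of hydrogen on an aromatic carbon. Going by the values given here, the sole step that bears on this change is the one between compound 1 and compound 2, a sulfanyl group entering at the same carbon without moving the number beyond the scatter, so no step beyond the scatter is expected in this assay here either. Compound 3 is therefore estimated at 60000 nM, within a range from 25000 nM to 150000 nM. The expected step is a 1.1-fold lower number from compound 1 to compound 3 (0.05 log units; within the scatter).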

Compound 3, half-maximal inhibitory concentration: 62100 nM
For compound 3 the middle estimate is 1.0-fold (0.01 log units) below the measured one, and the stated range covers the measured number.
By their numbers in this assay, from the lowest: compounds 2, 3 and 1 (each within the scatter of the next).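

At this aromatic carbon, between two ring nitrogen atoms, ethynylsulfanyl leaves the number in this assay within the scatter (a 1.1-fold lower number from compound 1 to compound 3 (0.04 log units; within the scatter)). With the sulfur kept, ethynyl in place of 4-nitrobenzyl also stays within the scatter (a 1.0-fold higher number from compound 2 to compound 3 (0.02 log units; within the scatter)), so these two very different groups on the sulfur cannot be told apart here. Nothing is available to explain this flat result.

On these data alone, what an amine or a carboxylic acid at this carbon, or a longer alkyl chain on the sulfur, would do to the number remains open.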